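A few compounds are considered here, and "the series" means these few. Any claim that something is new, unique, unknown or untested is made for them only; others in the source may bear on it.

In a functional assay on HepG2 cells (Homo sapiens) for antiproliferative activity, read by MTT assay, with a stated time of 24 h (a higher number here means a weaker inhibitor, a lower number a stronger inhibitor), compound 1 (`COc1ccc(C(=O)/C=C/c2cccc(F)c2)c2c1C=CC(C)(C)O2`) gives > 10000 nM, which is a limit of the assay and not a number. Compound 2 (`COc1ccc(/C=C/C(=O)c2ccc(OC)c3c2OC(C)(C)C=C3)cn1`) also gives only a limit, > 10000 nM. Everything measured so far therefore rests at the limit of > 10000 nM in this assay, at which 2 of the 2 values shown sit, and compound 2 has no numeric value to stand on. Compound 3 (`COc1ccc(C(=O)/C=C/c2cccc(Cl)c2)c2c1C=CC(C)(C)O2`) carries 3-chlorophenyl in place of 6-methoxypyridin-3-yl on a double-bonded chain carbon bound to a double-bonded chain carbon. Going by the values given here, the only measured step bearing on this change at the same place is a step that the two limits leave unreadable from compound 1 to compound 2, which offers no size to carry over. Both groups seen there left the compounds at the limit, so nothing in the data points to a gain in this assay, and a result at the limit is again the likeliest outcome. The expected change is a step that the limit leaves unreadable from compound 2 to compound 3, with no shift in either direction expected beyond the scatter. For compound 3 the estimated value is 15000 nM, with an expected range from 6000 nM to 40000 nM.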

Compound 3, half-maximal inhibitory concentration: > 10000 nM
Compound 3: only a limit was reported; the forecaster's own chance of this, stated with the estimate: 70%; the middle value is on the limit's open side.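

Compound 3, like compound 1 and compound 2, returns only a limit and not a number in this assay, so no step among these three compounds can be read: the limit of > 10000 nM in this assay, at which 3 of the 3 values shown sit.

The compounds shown leave open whether any change at this place on the shared core can give a measurable value in this assay.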